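The source may report more compounds than this note shows. Statements on the series, on what has been measured and on what is new or still open speak of the compounds shown alone.

Measured so far:
compound 1 `Cc1cc(COc2ccccc2Cl)nc(-c2ccccn2)n1` with 3.4
compound 2 `Cc1cc(COc2cccc(Cl)c2)nc(-c2ccccn2)n1` with 3.7
compound 3 `COc1ccccc1OCc1cc(C)nc(-c2ccccn2)n1` with 2.5

All three share a core and were tested in a physicochemical assay for lipophilicity, at pH 7.4; a higher number here means a more lipophilic compound, a lower number a more polar compound. Compound 1 and compound 2 have the same atoms joined differently; the difference between the two cores is 3-chlorophenyl in place of 2-chlorophenyl on an oxygen on a saturated carbon, and it gave a step of a number 0.30 log units higher from compound 1 to compound 2 (within the scatter). Compound 3 differs from compound 1 by methoxy in place of chloro on an aromatic carbon, which gave a step of a number 0.90 log units lower from compound 1 to compound 3 (beyond the scatter).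

Compound 4 `COc1cccc(OCc2cc(C)nc(-c3ccccn3)n2)c1` has not yet been measured in this assay. It differs from compound 2 by methoxy in place of chloro on an aromatic carbon. Among the measured compounds shown here, this is the same kind of change as the one from compound 1 to compound 3, but not the same: in compound 3 the new group sits ortho to a large group, while in compound 4 it sits meta to a large group. For the measured compounds named here, the step from compound 1 to compound 3 is the only measured example of this kind of change, so the expectation for compound 4 rests on that one step alone.

Starting from compound 2, a step of a number 0.90 log units lower from compound 2 to compound 4 (beyond the scatter) is expected, because the same kind of change gave a number 0.90 log units lower from compound 1 to compound 3 (beyond the scatter). For compound 4 the estimated value is therefore 2.8, with a range from 2.4 to 3.2.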

Compound 4, distribution coefficient: 2.9
For compound 4 the middle estimate is 0.10 log units below the measured one; low and high end bracket the measured number.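

In this assay, methoxy in place of chloro on an aromatic carbon gave a number 0.80 log units lower from compound 2 to compound 4 (beyond the scatter), and the same kind of change had given a number 0.90 log units lower from compound 1 to compound 3 (beyond the scatter), so the change went the same way in both pairs, although the new group is meta to a large group in compound 4 and sits elsewhere on the ring in compound 3. This shows that the change carried over between these two closely related compounds, but two pairs are a small base, and they do not show that it would carry over to a different core or to every place on the ring. Nothing among the data shown explains the direction or the size of either step.

As far as these compounds go, both pairs exchange only chloro for methoxy, so it remains open whether the same kind of comparison would hold for another entering group, such as an amine, a carboxylic acid or a longer chain like butoxy. From the compounds shown here alone, it also remains open whether the methoxy step would stay the same if the methyl group or the pyridine-bearing part of the shared structure were replaced by something else.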